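This account rests on a few compounds, and the source may have more. Where it says the series, first, only, none or still open, it means among the compounds named here.

Measured compounds:
compound 1 `CCOC(=O)Nc1nccc(-c2ccncc2)n1` — 31%
compound 2 `CC(=O)N(C(C)=O)c1ncc(-c2ccccc2)c(C(C)(C)C)n1` — 22%
compound 3 `CN(C)c1nccc(C(C)(C)C)n1` — 18%

All three were tested in a functional assay on the whole organism for inhibition, with Rattus norvegicus as the target, with stated times of 1 h and 3.5 h, at a dose of 100 mg/kg by the oral route; on this read-out lower numbers stand for less inhibition and higher numbers for more inhibition at the one dose given (going by the name of the read-out). Compound 3 gives the lowest of the three numbers. Compound 2 sits close to it, the two values lying within the usual scatter of repeated measurements, so no order between them can be claimed. Compound 1 stands farther off, with a gap beyond that scatter. The step of interest runs from compound 3 to compound 4 `CSc1nccc(C(C)(C)C)n1`, which has not yet been tested in this assay. The change is: methylsulfanyl in place of dimethylamino on an aromatic carbon. Among the measured compounds shown here, no measured pair here differs in just one place, so there is no earlier step of this kind to lean on. With one small group without a ring replaced by another small group without a ring, each carrying one hydrogen-bond acceptor, and compound 3 already giving 18%, the step is expected to be a number 1 percentage points lower from compound 3 to compound 4 (within the scatter), which amounts to no change beyond the scatter. Compound 4 is therefore estimated at 17%, within a range from 4% to 32%.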

Compound 4, a percentage reported as inhibition, in the whole organism at one dose (the size of the read-out at that dose, not a potency): 35%
Beside the measured number, compound 4's estimate is 18 percentage points below it, outside the stated range (above it).
By their numbers in this assay, from the lowest: compounds 3, 2, 1 and 4 (each within the scatter of the next, the first and the last beyond it).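

In this assay, putting methylsulfanyl in place of dimethylamino on the aromatic carbon between two ring nitrogen atoms gives a number 17 percentage points higher from compound 3 to compound 4 (beyond the scatter), and this is the first pair shown that differs in one place only. The number at this position therefore depends on which group sits there, even though neither group has a ring and both count the same hydrogen-bond donors and acceptors. Those counts alone do not settle the outcome for this pair, and nothing measured here tells what lies behind the step.

Still open, as far as these compounds go, is how other groups at this position would read, such as methoxy, a plain amine or the longer ethylsulfanyl chain. Also open, from the compounds shown here alone, is whether this change gives a similar step when a cyclopropyl group stands in place of the tert-butyl group.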